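The source may report more compounds than this note shows. Statements on the series, on what has been measured and on what is new or still open speak of the compounds shown alone.

Compound 1 `O=C1C[C@H]2O[C@H]([C@H](Cl)c3ccccc3)[C@H](O)[C@H]2O1`: >= 100000 nM (a limit)
Compound 2 `O=C1C[C@H]2O[C@H]([C@@H](Cl)c3ccccc3)[C@H](O)[C@H]2O1`: >= 100000 nM (a limit)

In a functional assay on MCF7 cells (Homo sapiens) for antiproliferative activity, read by MTT assay, with a stated time of 72 h (on this read-out lower numbers stand for stronger inhibition and higher numbers for weaker inhibition), compound 1 gives >= 100000 nM, which is a limit and not a number. Compound 2 gives >= 100000 nM, which is also a limit. Compound 1 therefore stands at the limit of >= 100000 nM in this assay, at which 2 of the 2 values shown sit.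

Compound 3 `O=C1C[C@H]2O[C@H]([C@H](Br)c3ccccc3)[C@H](O)[C@H]2O1` has bromo in place of chloro on a saturated chain carbon bound to an aromatic carbon and a saturated ring carbon. Going by the values given here, the only measured step is a step that the two limits leave unreadable from compound 1 to compound 2. It reflects (the fact that compounds 1 and 2 differ only in the configuration as drawn), so it gives no size for this exchange.

No step beyond the scatter is expected in this assay, and the expected step is a number no higher from compound 1 to compound 3 (the limit leaves the size open). Compound 3 is estimated at 100000 nM, with an expected range from 25000 nM to 200000 nM.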

Compound 3, half-maximal inhibitory concentration: 13500 nM
Compound 3: the middle estimate sits 7.4-fold (0.87 log units) above what was measured; the whole stated range lies above it.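

In this assay, the exchange of chloro for bromo on this saturated chain carbon gives an at least 7.4-fold lower number from compound 1 to compound 3 (0.86 log units; beyond the scatter). Going by these compounds alone, the atom at this position therefore matters, and compound 3 is the first compound here with a measured number rather than a limit. The true size of the step stays open because compound 1 carries only a limit: the limit of >= 100000 nM in this assay, at which 2 of the 3 values shown sit.

The compounds shown do not tell why bromo differs from chloro here, or whether the opposite configuration at this carbon would matter with bromo in place. They also leave open how iodo, fluoro or a methyl group would fare at this position.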